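Second Hydroxy on the Aryl Ring of Compound 3

The source may report more compounds than this note shows. Statements on the series, on what has been measured and on what is new or still open speak of the compounds shown alone.

Measured so far in a functional assay on SW 1116 cells (Homo sapiens) for cytotoxicity, read by MTT assay, with a stated time of 48 h; on this read-out lower numbers stand for stronger inhibition and higher numbers for weaker inhibition:
- compound 1, `O=C(CSc1nnc(-c2ccncc2)o1)N/N=C/c1ccc(Br)cc1`, gives 21300 nM
- compound 2, `O=C(CSc1nnc(-c2ccncc2)o1)N/N=C/c1ccc([N+](=O)[O-])cc1`, gives 25800 nM
- compound 3, `O=C(CSc1nnc(-c2ccncc2)o1)N/N=C/c1ccc(O)cc1`, gives 12200 nM

All three compounds share one core and differ only in a single group on the aryl ring that hangs off the hydrazone. Compound 3 carries the hydroxy group and shows the lowest of the three numbers: its step from compound 2 is a 2.1-fold lower number from compound 2 to compound 3 (0.33 log units; beyond the scatter), while its gap to compound 1, a 1.7-fold lower number from compound 1 to compound 3 (0.24 log units; within the scatter), is within the scatter, so compound 3 cannot be called the strongest of the set.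

Compound 4, `O=C(CSc1nnc(-c2ccncc2)o1)N/N=C/c1ccc(O)c(O)c1`, is the next step. The change from compound 3 is hydroxy in place of hydrogen on an aromatic carbon. A hydrogen atom leaves and a hydroxy group enters, so that the 4-hydroxyphenyl of compound 3 becomes a 3,4-dihydroxyphenyl; the new group sits ortho to the hydroxy group already present.

Among the compounds with values here, no measured pair shows a second hydroxy entering the same ring. The nearest precedents are the two steps in which a hydroxy replaced another group, a 1.7-fold lower number from compound 1 to compound 3 (0.24 log units; within the scatter) and a 2.1-fold lower number from compound 2 to compound 3 (0.33 log units; beyond the scatter), both small. A small step at most is therefore expected for compound 4, with no clear direction, leaning slightly lower: the estimated step is a 1.2-fold lower number from compound 3 to compound 4 (0.09 log units; within the scatter). For compound 4 the expected value in this assay is 10000 nM, with a range from 4000 nM to 25000 nM.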

Compound 4, half-maximal inhibitory concentration: 1540 nM
For compound 4 the middle estimate is 6.5-fold (0.81 log units) above the measured one, outside the stated range (below it).
By their numbers in this assay, from the lowest: compound 4; then compounds 3, 1 and 2 (each within the scatter of the next, the first and the last beyond it).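

In this assay, within the data shown here, the single added hydroxy group gives a 7.9-fold lower number from compound 3 to compound 4 (0.90 log units; beyond the scatter) and so shows that this aryl ring can carry a far lower number than compounds 1, 2 and 3 suggested. Among these compounds, those three differ only by which one group the ring carries, whereas compound 4 keeps the hydroxy group of compound 3 and gains a second one ortho to it, and this is the first change here to move the number by so much. The wider comparisons give a 17-fold lower number from compound 2 to compound 4 (1.22 log units; beyond the scatter) and a 14-fold lower number from compound 1 to compound 4 (1.14 log units; beyond the scatter) as well, so all three steps to compound 4 lie beyond the scatter and compound 4 is the strongest of the four in this assay by a clear margin.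

Going by these compounds, whether a methoxy group or an amine in the same place, ortho to the hydroxy group, would give a similar number stays open, as does whether the new hydroxy group would do the same on a ring without the first one. Nothing available here accounts for the size of this step.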